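Benzyl in place of 4-fluorophenoxy on the shared core

The source may hold more compounds than are shown below. What is called first, only, known or untested is meant among the compounds shown, and "the series" means these compounds.

- compound 1 `COc1cccc(CNCCCNc2ccnc3cc(Oc4ccccc4)ccc23)c1O`: 9.28
- compound 2 `COc1cccc(CNCCCNc2ccnc3cc(Cc4cccc(C(F)(F)F)c4)ccc23)c1O`: 9.47
- compound 3 `COc1cccc(CNCCCNc2ccnc3cc(Oc4ccc(F)cc4)ccc23)c1O`: 9.28

In a physicochemical assay for acid dissociation, compound 3 gives 9.28, level with compound 1 at the digits reported. None of the three compounds lies beyond the scatter from another.

The next structure, compound 4 `COc1cccc(CNCCCNc2ccnc3cc(Cc4ccccc4)ccc23)c1O`, has benzyl in place of 4-fluorophenoxy on an aromatic carbon of a six-membered aromatic ring of carbon only, part of a fused or bridged system of two rings: benzyl in place of 4-fluorophenoxy on an aromatic carbon.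

Among the compounds with values here, no measured step makes exactly this change. The nearest is a number 0.19 log units lower from compound 2 to compound 3 (within the scatter), where 4-fluorophenoxy replaces 3-(trifluoromethyl)benzyl. Its counterpart without the fluoro group is a number 0.19 log units higher from compound 1 to compound 2 (within the scatter). The fluoro group alone gives no change at the digits printed from compound 1 to compound 3 (within the scatter), so compound 1 and compound 3 offer the same starting level. Within the data shown here, compound 4 differs from compound 2 by lacking the trifluoromethyl group, and no measured pair isolates that group. A small rise in this assay is therefore expected, at most of the size seen with compound 2, and nothing beyond the scatter. The expected step is a number 0.07 log units higher from compound 3 to compound 4 (within the scatter). For compound 4 the estimated value is 9.35, with an expected range of 9.1 to 9.6.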

Compound 4, acid dissociation constant: 9.47
The estimate for compound 4 lay 0.12 log units below the measured number; measured number inside the range.
By their numbers in this assay, from the lowest: compounds 1, 3, 2 and 4 (each within the scatter of the next).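

Notes on this position: in this assay, the unsubstituted benzyl group now gives direct comparisons with both aryl ethers, with benzyl in place of phenoxy giving a number 0.19 log units higher from compound 1 to compound 4 (within the scatter) and benzyl in place of 4-fluorophenoxy giving a number 0.19 log units higher from compound 3 to compound 4 (within the scatter). Within the data shown here, the trifluoromethyl group is also isolated for the first time: hydrogen in its place gives no change at the digits printed from compound 2 to compound 4 (within the scatter), so at the digits printed this read-out does not separate benzyl from 3-(trifluoromethyl)benzyl. Phenoxy, 4-fluorophenoxy, benzyl and 3-(trifluoromethyl)benzyl therefore all sit within the scatter of one another at this aromatic carbon, and the four compounds give no ground for ranking these groups in this assay.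

No available evidence accounts for these readings. Still open is whether an amine, a carboxylic acid or a longer chain in place of benzyl on this aromatic carbon would move the number in this assay beyond the scatter, since the groups shown here do not test that.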